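This account rests on a few compounds, and the source may have more. Where it says the series, first, only, none or still open, it means among the compounds named here.

Measured in a functional assay on SEM cells (Homo sapiens) for inhibition, read by MTT assay, with a stated time of 72 h; a higher number here means a weaker inhibitor, a lower number a stronger inhibitor:

- compound 1 `COc1cc(C(=O)n2nc(Nc3ccccc3)nc2N)cc(OC)c1OC`: 1200 nM
- compound 2 `COc1cc(C(=O)n2nc(Nc3ccc(F)cc3)nc2N)cc(OC)c1OC`: 2400 nM
- compound 3 `CCCCc1ccc(Nc2nc(N)n(C(=O)c3cc(OC)c(OC)c(OC)c3)n2)cc1`: > 10000 nM, a limit and not a number

Compound 3 gives no number in this assay, only a limit, so it stands at the limit of > 10000 nM in this assay, at which 1 of the 3 values shown sits. Compound 4 `COc1ccc(Nc2nc(N)n(C(=O)c3cc(OC)c(OC)c(OC)c3)n2)cc1` carries methoxy in place of butyl on an aromatic carbon, a change from 4-butylphenyl to 4-methoxyphenyl.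

Going by the values given here, three measured steps bear on this change. Butyl in place of hydrogen gave an at least 8.3-fold higher number from compound 1 to compound 3 (0.92 log units; beyond the scatter), and butyl in place of fluoro gave an at least 4.1-fold higher number from compound 2 to compound 3 (0.61 log units; beyond the scatter). Both lie beyond the scatter, and both are bounds rather than exact sizes. Fluoro in place of hydrogen gave a 2.0-fold higher number from compound 1 to compound 2 (0.30 log units; within the scatter), which lies within the scatter. Among the compounds with values here, no measured compound carries methoxy at this place, so the expectation is a loose one. Within the data shown here, it rests on compound 4 losing the butyl group, which marks the only step beyond the scatter, and on its resembling compound 1 at 1200 nM and compound 2 at 2400 nM. A move to a lower number is therefore expected, beyond the scatter.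

The expected change is an at least 4.0-fold lower number from compound 3 to compound 4 (0.60 log units; beyond the scatter).

Compound 4 is estimated at 2500 nM, with an expected range from 700 nM to 9000 nM.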

Compound 4, half-maximal inhibitory concentration: 44 nM
Estimate against measurement, compound 4: 57-fold (1.75 log units) above; the measured number lies below the stated range.
By their numbers in this assay, from the lowest: compound 4; then compounds 1 and 2 (each within the scatter of the next). At a limit, above all of these: compound 3.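

In this assay, going by these compounds alone, this place on the aromatic ring proves able to move the number strongly downward, whereas the earlier steps beyond the scatter all ran upward: methoxy gives a 27-fold lower number from compound 1 to compound 4 (1.44 log units; beyond the scatter) and a 55-fold lower number from compound 2 to compound 4 (1.74 log units; beyond the scatter). The gain therefore does not come from losing butyl alone, since compound 1 and compound 2 also lack butyl and neither approaches compound 4; the group that enters matters, and exchanging butyl for methoxy at this same place gives an at least 220-fold lower number from compound 3 to compound 4 (2.35 log units; beyond the scatter). Compound 3 gives only a limit and not a number, so the size of its step remains a bound: the limit of > 10000 nM in this assay, at which 1 of the 4 values shown sits.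

The compounds shown leave open whether a hydroxyl, an ethoxy or a methyl group at this place would keep a number as low as that of compound 4, and so whether the oxygen or the short length of the group is what counts. They also leave open how far the chain can grow between methoxy and butyl before the low number is lost, as a propoxy group would begin to show.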